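Returning the hydroxycarbamoyl group on a longer chain

The source may report more compounds than this note shows. Statements on the series, on what has been measured and on what is new or still open speak of the compounds shown alone.

Measured compounds:
compound 1 `Cn1cc(-c2ccccc2Oc2ccccc2)c2cc(C(=O)NCCCC(=O)NO)[nH]c2c1=O` 144 nM
compound 2 `Cn1cc(-c2ccccc2Oc2ccccc2)c2cc(C(=O)NCc3ccc(C(=O)NO)cc3)[nH]c2c1=O` 15.3 nM
compound 3 `Cn1cc(-c2ccccc2Oc2ccccc2)c2cc(C(=O)NCCCCCC(=O)Nc3ccccc3N)[nH]c2c1=O` > 500 nM

In an assay on isolated protein for inhibition of protein deacetylase HDAC6 (Homo sapiens), read by fluorescence (a higher number here means a weaker inhibitor, a lower number a stronger inhibitor), compound 3 gives only a limit, > 500 nM, and no number. Going by the values given here, it is the one compound of the three that sits at that limit (the limit of > 500 nM in this assay, at which 1 of the 3 values shown sits). The step from compound 1 leads there: an at least 3.4-fold higher number from compound 1 to compound 3 (0.54 log units; beyond the scatter). In the other direction, compound 2 shows how much a change of the chain end can alter this assay: a 9.4-fold lower number from compound 1 to compound 2 (0.97 log units; beyond the scatter).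

Compound 4 `Cn1cc(-c2ccccc2Oc2ccccc2)c2cc(C(=O)NCCCCC(=O)NO)[nH]c2c1=O` is not yet measured. It differs from compound 3 in one place: hydroxycarbamoyl in place of ((2-aminophenyl)carbamoyl)methyl on a saturated chain carbon, four bonds along the chain from an amide-type nitrogen. This largely reverses the change that took compound 1 to compound 3, while keeping a chain one carbon longer than that of compound 1. The step from compound 1 to compound 3 therefore bears most directly on it, and it was at least modest and upward; undoing it is expected to bring the number back down by a comparable amount, so that compound 4 is expected to show an at least 4.5-fold lower number from compound 3 to compound 4 (0.65 log units; beyond the scatter) in this assay. How far the extra chain carbon moves the number relative to compound 1 cannot be read from the compounds measured. Compound 4 is accordingly estimated at 110 nM, with a range from 30 nM to 400 nM.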

Compound 4, half-maximal inhibitory concentration: 4 nM
Compound 4: the middle estimate sits 28-fold (1.44 log units) above what was measured; the measured number lies below the stated range.
By their numbers in this assay, from the lowest: compound 4; then compound 2; then compound 1. At a limit, above all of these: compound 3.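

In this assay, lengthening the chain that carries the hydroxycarbamoyl group, with (hydroxycarbamoyl)methyl in place of hydroxycarbamoyl, gives a 36-fold lower number from compound 1 to compound 4 (1.56 log units; beyond the scatter), so chain length alone moves this number strongly, and the flexible chain of compound 4 also outdoes the aromatic linker of compound 2, with 3-(hydroxycarbamoyl)propyl in place of 4-(hydroxycarbamoyl)phenyl giving a 3.8-fold lower number from compound 2 to compound 4 (0.58 log units; beyond the scatter). Going by these compounds alone, replacing ((2-aminophenyl)carbamoyl)methyl with hydroxycarbamoyl at this place gives an at least 120-fold lower number from compound 3 to compound 4 (2.09 log units; beyond the scatter), a far larger change than the earlier compounds had indicated for this end group and chain. The size of that step is only a lower bound, as compound 3 gives a limit and no number: the limit of > 500 nM in this assay, at which 1 of the 4 values shown sits.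

The step from compound 3 changes both the chain end and the chain length, so the compounds shown do not separate the share of each, which the (2-aminophenyl)carbamoyl group on the chain of compound 4 would do. They also leave open whether a still longer chain bearing hydroxycarbamoyl would lower the number further, and how a carboxylic acid at the chain end would compare.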